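This account rests on a few compounds, and the source may have more. Where it says the series, first, only, none or still open, it means among the compounds named here.

Working notes on the series, read in a physicochemical assay for solubility; a lower number here means a less soluble compound, a higher number a more soluble compound. Compound 3 `O=C(Nc1nc(-c2cccc(C(F)(F)F)c2F)cs1)c1cnc(N2CCNC(C(=O)O)C2)c(Cl)c1` gives < 10 ug/mL, which is a limit and not a number. Compound 1 `NC(=O)C1CCN(c2ncc(C(=O)Nc3nc(-c4cccc(C(F)(F)F)c4F)cs3)cc2Cl)CC1` gives < 10 ug/mL, also a limit. Compound 2 `C[C@H]1CN(c2ncc(C(=O)Nc3nc(-c4cccc(C(F)(F)F)c4F)cs3)cc2Cl)CC1C(=O)O` gives < 10 ug/mL, again a limit. The measured set as a whole shows (the limit of < 10 ug/mL in this assay, at which 3 of the 3 values shown sit), so compound 3 has no readable place of its own within it.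

The next compound is compound 4 `O=C(Nc1nc(-c2cccc(C(F)(F)F)c2F)cs1)c1cnc(N2CCCC(C(=O)O)C2)c(Cl)c1`. The change is 3-carboxypiperidin-1-yl in place of 3-carboxypiperazin-1-yl on an aromatic carbon, with 3-carboxypiperidin-1-yl in place of 3-carboxypiperazin-1-yl on an aromatic carbon, next to the ring nitrogen and ortho to a chloro group.

Three measured steps change the group at this same place: a step that the two limits leave unreadable from compound 1 to compound 2, a step that the two limits leave unreadable from compound 1 to compound 3 and a step that the two limits leave unreadable from compound 2 to compound 3. None of them has a readable size, so the data give no measured size or direction for the change at hand. The expectation therefore rests on a step that the two limits leave unreadable from compound 2 to compound 3 and on (the limit of < 10 ug/mL in this assay, at which 3 of the 3 values shown sit), and no step beyond the scatter is expected in this assay. The expected step is a step that the limit leaves unreadable from compound 3 to compound 4. Compound 4 is estimated at 6 ug/mL, with an expected range from 2 ug/mL to 15 ug/mL, and a report as a limit is the likeliest outcome.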

Compound 4, solubility: < 10 ug/mL
Compound 4: only a limit was reported (the forecaster's own chance of this, stated with the estimate: 80%); the middle value lies beyond the limit too.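

In this assay compound 4 gives < 10 ug/mL, which is a limit. Among the compounds shown here, no step from compound 1, compound 2 or compound 3 to compound 4 can be read. The compounds shown leave open how far the groups at this place differ in this assay, since the whole set stands at one limit: the limit of < 10 ug/mL in this assay, at which 4 of the 4 values shown sit.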